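Working notes on a shared core and its benzyl variants

The compounds below may be only part of what the source reports. "The series", "measured", "known", "first", "only" and "open" are said of these compounds alone.

Compound 1 `O=C1/C(=C/c2ccccc2F)CN(C(=S)SCc2cn(Cc3cccc(Cl)c3)nn2)C/C1=C\c1ccccc1F` has been read in a functional assay on MCF7 cells (Homo sapiens) for cytotoxicity, read by MTT assay, with a stated time of 24 h; on this read-out lower numbers stand for stronger inhibition and higher numbers for weaker inhibition. In this assay compound 1 gives > 100000 nM, which is a limit of the assay and not a number. Compound 2 `Cc1ccc(/C=C2\CN(C(=S)SCc3cn(Cc4ccccc4F)nn3)C/C(=C\c3ccc(C)cc3)C2=O)cc1` differs from compound 1 in more than one place and is therefore not a single step. In this assay compound 2 gives > 100000 nM, again a limit. Both measured values therefore sit together (the limit of > 100000 nM in this assay, at which 2 of the 2 values shown sit), so compound 1 stands at the limit, with no numbered step between measured compounds and no ranking of compound 1 against compound 2 possible.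

Compound 3 `O=C1/C(=C/c2ccccc2F)CN(C(=S)SCc2cn(Cc3ccccc3F)nn2)C/C1=C\c1ccccc1F` is not yet measured. Relative to compound 1 the change is 2-fluorophenyl in place of 3-chlorophenyl on a saturated chain carbon bound to an aromatic nitrogen. Going by the values given here, compound 2 carries the same 2-fluorobenzyl group on the aromatic nitrogen, and compound 2 shows only a limit; nothing among the measured values points to a move off the limit. The step from compound 1 to compound 3 is expected to be none beyond the scatter, a step that the limit leaves unreadable from compound 1 to compound 3, with the result most likely again a limit. Compound 3 is estimated at 150000 nM, within a range of 50000 nM to 600000 nM.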

Compound 3, half-maximal inhibitory concentration: 51600 nM
Compound 3: the middle estimate sits 2.9-fold (0.46 log units) above what was measured, and the stated range covers the measured number.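

Going by these compounds alone, at this position, on a saturated chain carbon bound to an aromatic nitrogen, replacing 3-chlorobenzyl with 2-fluorobenzyl gives the first reading in this assay that is a number and not a limit. As far as these compounds go, the change reads as an at least 1.9-fold lower number from compound 1 to compound 3 (0.28 log units; that floor lies within the scatter); only a floor is known, the true size stays unknown, and the floor alone does not establish a change beyond the scatter. This one number is still the exception among the values shown, and the position cannot yet be ranked beyond this single pair: the limit of > 100000 nM in this assay, at which 2 of the 3 values shown sit.

The step changes the halogen and its numbered place on the phenyl ring together, so the compounds shown cannot separate the two, and a pair such as 2-chlorobenzyl and 3-fluorobenzyl on the shared core would be needed to tell them apart. Also open, from the compounds shown here alone, is whether an unsubstituted benzyl, a longer chain such as 2-phenylethyl, or a chain carrying an amine at this position would give a number at all, and whether any such number would lie beyond the scatter of compound 3.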